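Furan-3-yl in Place of Pyrimidin-2-yl on the Shared Core

The source may report more compounds than this note shows. Statements on the series, on what has been measured and on what is new or still open speak of the compounds shown alone.

Compound 1 `Cc1cccc(-c2ccccc2OCC2=NCCN2)n1`: in a functional assay for activation of Alpha-1D adrenergic receptor (Homo sapiens), read by calcium flux (on this read-out higher numbers stand for an effect only at larger amounts of compound and lower numbers for an effect already at smaller amounts), compound 1 gives < 100000 nM, a limit of the assay and not a number.
Compound 2 `c1cnc(-c2ccccc2OCC2=NCCN2)nc1`: in this assay compound 2 gives < 100000 nM, again only a limit.

Compound 2 therefore stands on the assay limit alone. Among the compounds with values here, both values shown fall at the limit of < 100000 nM in this assay, at which 2 of the 2 values shown sit, so no measured step separates them. Compound 3 `c1ccc(-c2ccoc2)c(OCC2=NCCN2)c1` differs from compound 2 by furan-3-yl in place of pyrimidin-2-yl on an aromatic carbon. With nothing measured to build on, no shift beyond the scatter is expected in this assay, and the step that the limit leaves unreadable from compound 2 to compound 3 is an estimate only. Compound 3 is expected at about 10000 nM, between 1000 nM and 100000 nM.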

Compound 3, half-maximal effective concentration: 5.01 nM
The estimate for compound 3 lay 2000-fold (3.30 log units) above the measured number; measured number outside the range, below it.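

No step from compound 2 to compound 3 can be read in this assay, because the value of compound 2 is only a limit of the assay: the limit of < 100000 nM in this assay, at which 2 of the 3 values shown sit.

The compounds shown leave open how large the effect of furan-3-yl in place of pyrimidin-2-yl on the shared core actually is.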